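Acyl variation on the shared core: thiazole for pyridine

The source may report more compounds than this note shows. Statements on the series, on what has been measured and on what is new or still open speak of the compounds shown alone.

Compound 3 `CCCCNc1nc(N)nc2c1CN(C(=O)c1ccccn1)CC2` carries a (pyridin-2-yl)carbonyl on the amide-type nitrogen in the ring of the shared core. Going by the values given here, in an assay on HEK293 cells for agonist activity at Toll-like receptor 8 (Homo sapiens), read by a luciferase reporter, with a stated time of 6 h (on this read-out higher numbers stand for an effect only at larger amounts of compound and lower numbers for an effect already at smaller amounts), compound 3 gives 2.9 uM, the highest of the three numbers measured so far. The benzyl analogue compound 1 `CCCCNc1nc(N)nc2c1CN(Cc1ccccc1)CC2` gives 0.06 uM in this assay, and the 2-chlorobenzyl analogue compound 2 `CCCCNc1nc(N)nc2c1CN(Cc1ccccc1Cl)CC2` gives 0.05 uM. The acyl substitution registers as a 48-fold higher number from compound 1 to compound 3 (1.68 log units; beyond the scatter) and as a 58-fold higher number from compound 2 to compound 3 (1.76 log units; beyond the scatter), whereas a 1.2-fold lower number from compound 1 to compound 2 (0.08 log units; within the scatter).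

Compound 4 `CCCCNc1nc(N)nc2c1CN(C(=O)c1scnc1C)CC2` differs from compound 3 in one place: 4-methyl-1,3-thiazol-5-yl in place of pyridin-2-yl on a carbonyl carbon. Among the compounds with values here, no measured step exchanges one carbonyl-borne aromatic ring for another; the two steps that reach compound 3 both concern the move from a benzyl-type group to the acyl group and say nothing about which ring sits on the carbonyl. With the carbonyl retained, the number for compound 4 is expected to stay near that of compound 3, so a 1.0-fold higher number from compound 3 to compound 4 (0.01 log units; within the scatter) is expected to fall within the scatter. Compound 4 is estimated at 3 uM, with a range from 1 uM to 10 uM in this assay.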

Compound 4, minimum effective concentration: 5.6 uM
For compound 4 the middle estimate is 1.9-fold (0.27 log units) below the measured one, and the stated range covers the measured number.
By their numbers in this assay, from the lowest: compounds 2 and 1 (each within the scatter of the next); then compounds 3 and 4 (each within the scatter of the next).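

In this assay, the exchange of one aromatic ring for another on the carbonyl carbon gives a 1.9-fold higher number from compound 3 to compound 4 (0.29 log units; within the scatter), so pyridin-2-yl and 4-methyl-1,3-thiazol-5-yl are not told apart at this position. The large step away from the benzyl-type groups now appears with a second acyl group: a 93-fold higher number from compound 1 to compound 4 (1.97 log units; beyond the scatter) and a 110-fold higher number from compound 2 to compound 4 (2.05 log units; beyond the scatter), so it is not confined to the (pyridin-2-yl)carbonyl group. No measurement at hand offers an explanation for either finding.

Open, going by these compounds, is whether the large steps go with the carbonyl itself or with the aromatic ring it carries; an acetyl group or a benzoyl group on the same nitrogen would bear on this. Also open, on these data alone, is how a benzyl group carrying an amine or a carboxylic acid would read out on the shared core.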